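Oxan-4-yl in Place of 2-Fluorophenyl: Toxicity Outlook

The source may hold more compounds than are shown below. What is called first, only, known or untested is meant among the compounds shown, and "the series" means these compounds.

Compound 1 `CCC(=O)Nc1ncc(-c2ccc(OC)cc2)n1C` and compound 2 `COc1ccc(-c2cnc(NC(=O)c3ccccc3F)n2C)cc1` share one core and differ only at the amide carbonyl. In a toxicity assay on THP-1 cells (Homo sapiens) for inhibition (on this read-out lower numbers stand for higher toxicity in this test and higher numbers for lower toxicity in this test), compound 1 gives no number, only a limit, > 100000 nM. In this assay compound 2 likewise gives only a limit, > 100000 nM. The step that the two limits leave unreadable from compound 1 to compound 2 thus cannot be read. Compound 3 `COc1ccc(-c2cnc(NC(=O)C3CCOCC3)n2C)cc1` carries the change (oxan-4-yl in place of 2-fluorophenyl on a carbonyl carbon). Going by the values given here, both measured values rest on (the limit of > 100000 nM in this assay, at which 2 of the 2 values shown sit), so no step bears on this change. The expected step is a step that the limit leaves unreadable from compound 2 to compound 3, nothing beyond the scatter. Compound 3 is therefore estimated at 150000 nM, within 50000 nM to 500000 nM.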

Compound 3, half-maximal cytotoxic concentration: > 100000 nM
Compound 3: only a limit was reported (the forecaster's own chance of this, stated with the estimate: 85%); the middle value does not contradict the limit.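

Going by these compounds alone, compound 1, compound 2 and compound 3 all give only a limit in this assay, so no step among them can be read. The compounds shown leave open whether any group on the carbonyl carbon alters toxicity in this test.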